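From Methoxyphenyl to Cyanophenyl: an Expected Cytotoxicity Shift

This account rests on a few compounds, and the source may have more. Where it says the series, first, only, none or still open, it means among the compounds named here.

Three compounds share one core and differ only in the aromatic group attached to it: compound 1 `CN(C)CCCCOC(=O)Nc1ccc(Cn2nc(-c3cncnc3)c3ccccc3c2=O)cc1`, compound 2 `CN(C)CCCCOC(=O)Nc1ccc(Cn2nc(-c3cnn(C)c3)c3ccccc3c2=O)cc1` and compound 3 `COc1ccc(-c2nn(Cc3ccc(NC(=O)OCCCCN(C)C)cc3)c(=O)c3ccccc23)cc1`. In an ADME assay on Huh-7 cells (Homo sapiens) for cytotoxicity, read by MTT assay, with a stated time of 48 h (on this read-out lower numbers stand for higher toxicity in this test and higher numbers for lower toxicity in this test), compound 1 gives 65300 nM, compound 2 gives 55900 nM, and compound 3 gives 20300 nM, the lowest of the three numbers. The steps of a 3.2-fold lower number from compound 1 to compound 3 (0.51 log units; beyond the scatter) and a 2.8-fold lower number from compound 2 to compound 3 (0.44 log units; beyond the scatter) are both modest and beyond the scatter, while a 1.2-fold lower number from compound 1 to compound 2 (0.07 log units; within the scatter) lies within it. Compound 4 `CN(C)CCCCOC(=O)Nc1ccc(Cn2nc(-c3cccc(C#N)c3)c3ccccc3c2=O)cc1` carries 3-cyanophenyl in place of 4-methoxyphenyl on an aromatic carbon. Among the measured compounds shown here, no measured step exchanges one aromatic ring for another of this kind; the two steps that bear on it show that arriving at 4-methoxyphenyl lowered the number modestly, so leaving it is expected to raise the number slightly, if at all. Compound 4 is therefore expected to give 32000 nM, within 13000 nM to 75000 nM. That estimate means a 1.6-fold higher number from compound 3 to compound 4 (0.20 log units; within the scatter).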

Compound 4, half-maximal cytotoxic concentration: 17200 nM
For compound 4 the middle estimate is 1.9-fold (0.27 log units) above the measured one, and the stated range covers the measured number.
By their numbers in this assay, from the lowest: compounds 4 and 3 (each within the scatter of the next); then compounds 2 and 1 (each within the scatter of the next).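

In this assay the step of a 1.2-fold lower number from compound 3 to compound 4 (0.07 log units; within the scatter) puts 3-cyanophenyl level with 4-methoxyphenyl at this position, so a second six-membered aromatic ring of carbon only, with a different substituent, falls within the scatter of the first. Compound 4 also stands apart from the two rings containing nitrogen, as the modest steps of a 3.3-fold lower number from compound 2 to compound 4 (0.51 log units; beyond the scatter) and a 3.8-fold lower number from compound 1 to compound 4 (0.58 log units; beyond the scatter) show. No evidence is available to explain this separation. The compounds shown leave open whether unsubstituted phenyl, or a phenyl ring carrying an amine or a carboxylic acid, would fall with compounds 3 and 4 or with compounds 1 and 2.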